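This account rests on a few compounds, and the source may have more. Where it says the series, first, only, none or still open, it means among the compounds named here.

Measured so far in an ADME assay on HEK-293T cells (Homo sapiens) for inhibition, read by CCK-8 assay, with a stated time of 48 h, tested at 20 uM; on this read-out higher numbers stand for more inhibition of growth at the one concentration tested and lower numbers for less inhibition of growth:
compound 1 `COc1ccc(Cc2nnc(NC(=O)/C(C#N)=C/c3ccccc3OS(=O)(=O)c3ccc(Cl)cc3)s2)cc1`: 34%
compound 2 `COc1ccc(Cc2nnc(NC(=O)/C(C#N)=C/c3ccccc3OS(=O)(=O)c3ccc(F)cc3)s2)cc1`: 6%
compound 3 `N#C/C(=C\c1ccccc1OS(=O)(=O)c1ccc(Cl)cc1)C(=O)Nc1nnc(Cc2cccc3ccccc23)s1`: 16%

Compound 1 and compound 2 share a core and differ only in fluoro in place of chloro on an aromatic carbon; this change gave a number 28 percentage points lower from compound 1 to compound 2 (beyond the scatter). Compound 3 carries a different core; how the two cores differ is naphthalen-1-yl in place of 4-methoxyphenyl on a saturated chain carbon bound to an aromatic carbon, and this gave a number 18 percentage points lower from compound 1 to compound 3 (beyond the scatter). The values of compound 2 and compound 3 lie within the scatter of each other, so no order between them is claimed.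

Compound 4 `N#C/C(=C\c1ccccc1OS(=O)(=O)c1ccc(F)cc1)C(=O)Nc1nnc(Cc2cccc3ccccc23)s1` is not yet measured. It differs from compound 3 by fluoro in place of chloro on an aromatic carbon, the same change as from compound 1 to compound 2, at a place described in the same words. On the second core the step is expected to be smaller, because compound 3 already gives 16% and there is little room for the number to fall by as much as a number 28 percentage points lower from compound 1 to compound 2 (beyond the scatter). The expected step is a number 11 percentage points lower from compound 3 to compound 4 (beyond the scatter). Compound 4 is therefore estimated at 5%, between -8% and 18%, resting on the two measured steps only.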

Compound 4, percent growth inhibition at one concentration: 15%
Estimate against measurement, compound 4: 10 percentage points below; measured number inside the range.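

In this assay, fluoro in place of chloro on the core of compound 3 gave a number 1 percentage points lower from compound 3 to compound 4 (within the scatter), so the size of this step does not carry over from the core of compound 1: the same change on two cores in this assay, a number 28 percentage points lower (beyond the scatter) from compound 1 to compound 2 and a number 1 percentage points lower (within the scatter) from compound 3 to compound 4, 27 percentage points apart, beyond the scatter of two such steps

Naphthalen-1-yl in place of 4-methoxyphenyl likewise behaved differently in the fluoro pair, giving a number 9 percentage points higher from compound 2 to compound 4 (within the scatter), and the step seen in the chloro pair does not carry over either: the same change on two cores in this assay, a number 18 percentage points lower (beyond the scatter) from compound 1 to compound 3 and a number 9 percentage points higher (within the scatter) from compound 2 to compound 4, 27 percentage points apart, beyond the scatter of two such steps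

Both comparisons rest on the same four compounds, so they record one failure of the two changes to add up rather than two independent findings, and they show neither why this happens nor whether it would recur on any other core.

Open, on these data alone, is whether bromo or trifluoromethyl in place of chloro on that aromatic carbon would follow the large step of the core of compound 1 or the step within the scatter of the core of compound 3. Also open, as far as these compounds go, is what an amine or a carboxylic acid in place of 4-methoxyphenyl would give, and whether these steps would hold at other concentrations.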